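The source may hold more compounds than are shown below. What is called first, only, known or untested is meant among the compounds shown, and "the series" means these compounds.

Of the compounds shown here, three that share the same core have been measured in a functional assay on PC-3 cells (Homo sapiens) for inhibition, read by MTT assay, with a stated time of 72 h; a lower number here means a stronger inhibitor, a higher number a weaker inhibitor; a fourth has not. Compound 1 `CC(C)n1ncc2c(C(=O)NCc3cn(-c4ccc(F)cc4)nn3)cccc21` carries a 4-fluorophenyl, compound 2 `Cc1ccc(-n2cc(CNC(=O)c3cccc4c3cnn4C(C)C)nn2)cc1` a 4-methylphenyl and compound 3 `Cc1ccccc1-n1cc(CNC(=O)c2cccc3c2cnn3C(C)C)nn1` a 2-methylphenyl.

In this assay compound 1 gives only a limit, > 40000 nM, not a number. Compound 2 gives 39000 nM and compound 3 gives 19200 nM. Compound 2 and compound 3 are built from the same atoms joined differently: 2-methylphenyl in place of 4-methylphenyl on an aromatic nitrogen. That change produced a 2.0-fold lower number from compound 2 to compound 3 (0.31 log units; beyond the scatter). Compound 2 and compound 1 differ in one group: fluoro in place of methyl on an aromatic carbon. That step reads an at least 1.0-fold higher number from compound 2 to compound 1 (0.01 log units; that floor lies within the scatter), so exchanging methyl for fluoro there gave nothing that can be told apart from the scatter.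

Compound 4 `CC(C)n1ncc2c(C(=O)NCc3cn(-c4ccccc4F)nn3)cccc21` is the one not yet measured; it differs from compound 3 in the same way: fluoro in place of methyl on an aromatic carbon. This is the same kind of change as from compound 2 to compound 1, but the place is not identical: in compound 1 the fluoro sits para to a large group, in compound 4 ortho to a large group. Nothing measured here shows whether that difference in place matters. Because an at least 1.0-fold higher number from compound 2 to compound 1 (0.01 log units; that floor lies within the scatter) stayed within the scatter, a step of about a 1.3-fold higher number from compound 3 to compound 4 (0.11 log units; within the scatter) is expected. Compound 4 is therefore estimated at 25000 nM, with a likely range from 10000 nM to 60000 nM. Given (the limit of > 40000 nM in this assay, at which 1 of the 3 values shown sits), compound 4 may also be reported only as a limit.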

Compound 4, half-maximal inhibitory concentration: > 40000 nM
Compound 4 gave a limit, no number; the forecaster's own chance of this, stated with the estimate: 35%; at least 1.6-fold (0.20 log units) between middle value and limit.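

In this assay compound 4 gives only a limit, > 40000 nM, not a number, and the steps that join one limit to another cannot be read. With fluoro in place of methyl ortho to a large group, the result is an at least 2.0-fold higher number from compound 3 to compound 4 (0.31 log units; beyond the scatter), a real loss that can be stated only as a minimum, while the comparison with the 4-methylphenyl gives only an at least 1.0-fold higher number from compound 2 to compound 4 (0.01 log units; that floor lies within the scatter), which says nothing firm. So in this small series the methyl-to-fluoro change cannot be carried from one compound pair to the other as a step of known size, and the data neither show that the two places behave alike nor that they behave differently: the same change on two cores in this assay, an at least 1.0-fold higher number (0.01 log units; that floor lies within the scatter) from compound 2 to compound 1 and an at least 2.0-fold higher number (0.31 log units; beyond the scatter) from compound 3 to compound 4; the limit leaves it open whether they differ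

From the compounds shown here alone, compound 3 gives 19200 nM, and it remains open whether another group in place of its methyl, such as chloro, methoxy or an amine, would bring the number lower. Any finer comparison among these compounds is held back by one plain fact: the limit of > 40000 nM in this assay, at which 2 of the 4 values shown sit.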